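Furan to Thiophene Exchange on Two Different Arms

This account rests on a few compounds, and the source may have more. Where it says the series, first, only, none or still open, it means among the compounds named here.

In a functional assay on A-431 cells (Homo sapiens) for inhibition, read by sulforhodamine B assay, with a stated time of 2 days (on this read-out lower numbers stand for stronger inhibition of growth and higher numbers for weaker inhibition of growth), compound 1 `CC1=C(C(=O)Nc2cccc([N+](=O)[O-])c2)C(c2ccc(O)cc2O)NC(N/N=C/c2ccco2)=N1` gives 2910 nM. Compound 2 `CC1=C(C(=O)Nc2cccc([N+](=O)[O-])c2)C(c2ccc(O)cc2O)NC(N/N=C/c2cccs2)=N1` carries thiophen-2-yl in place of furan-2-yl on a carbon with a double bond to nitrogen and in this assay compound 2 gives 19100 nM, so that a 6.6-fold higher number from compound 1 to compound 2 (0.82 log units; beyond the scatter). Compound 3 `CC1=C(C(=O)Nc2cccc([N+](=O)[O-])c2)C(c2ccc(O)cc2O)NC(NN2C(=O)/C(=C\c3ccco3)SC2=S)=N1` shares the same core but the difference between the two cores is not broken down here; in this assay compound 3 gives 28900 nM, the highest of the three numbers. Compound 4 `CC1=C(C(=O)Nc2cccc([N+](=O)[O-])c2)C(c2ccc(O)cc2O)NC(NN2C(=O)/C(=C\c3cccs3)SC2=S)=N1` is related to compound 3 by thiophen-2-yl in place of furan-2-yl on a double-bonded chain carbon bound to a double-bonded ring carbon. This is the same kind of change as between compound 1 and compound 2, yet the place differs: there the ring sat on a carbon with a double bond to nitrogen, here on a double-bonded chain carbon bound to a double-bonded ring carbon. Because a 6.6-fold higher number from compound 1 to compound 2 (0.82 log units; beyond the scatter), a step in the same direction is expected, and the estimated step is a 2.4-fold higher number from compound 3 to compound 4 (0.38 log units; beyond the scatter). Compound 4 is thus expected to give about 70000 nM, within 25000 nM to 250000 nM.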

Compound 4, concentration for 50% growth inhibition: 2780 nM
Beside the measured number, compound 4's estimate is 25-fold (1.40 log units) above it, and the stated range ends above it.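

In this assay, thiophen-2-yl in place of furan-2-yl on a double-bonded chain carbon bound to a double-bonded ring carbon gives a 10-fold lower number from compound 3 to compound 4 (1.02 log units; beyond the scatter), which runs opposite to the step seen on the other core. The exchange thus did not carry from one core to the other, not even in direction: the same change on two cores in this assay, a 6.6-fold higher number (0.82 log units; beyond the scatter) from compound 1 to compound 2 and a 10-fold lower number (1.02 log units; beyond the scatter) from compound 3 to compound 4, 68-fold (1.83 log units) apart, beyond the scatter of two such steps. For the compounds shown here, this rests on only two pairs, and it shows neither what sets the direction of the step nor whether either direction holds for other members.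

The compounds shown leave open how a phenyl ring or a pyridine ring would compare with furan-2-yl and thiophen-2-yl on each core. Going by these compounds, whether the reversal would persist with those rings also remains open.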